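Compound 2 to compound 4: methoxy for trifluoromethyl

The compounds below may be only part of what the source reports. "The series", "measured", "known", "first", "only" and "open" are said of these compounds alone.

Measured in an ADME assay on microsomes from liver (Homo sapiens) for metabolic stability; a higher number here means that the compound lasts longer, a lower number that the compound disappears faster:
- compound 1 `COc1cc(OCc2csc(-c3ccc(C(F)(F)F)cc3)n2)c2cc(-c3cn4nc(OC)sc4n3)oc2c1`: > 2 h (a limit of the assay)
- compound 2 `COc1cc(OCc2cccc(-c3ccc(C(F)(F)F)cn3)c2)c2cc(-c3cn4nc(OC)sc4n3)oc2c1`: 0.733 h
- compound 3 `COc1cc(OCc2csc(-c3ccc(C(N)=O)cc3)n2)c2cc(-c3cn4nc(OC)sc4n3)oc2c1`: 1.38 h

In this assay compound 2 gives 0.733 h, and compound 3 lies within the scatter of it at 1.38 h. Compound 1 reports only a limit, > 2 h.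

Compound 4 `COc1ccc(-c2cccc(COc3cc(OC)cc4oc(-c5cn6nc(OC)sc6n5)cc34)c2)nc1` differs from compound 2 as follows: methoxy in place of trifluoromethyl on an aromatic carbon. This places methoxy on an aromatic carbon where trifluoromethyl stood.

Within the data shown here, the one measured step that removes trifluoromethyl is an at least 1.4-fold lower number from compound 1 to compound 3 (0.16 log units; that floor lies within the scatter), with carbamoyl in place of trifluoromethyl on an aromatic carbon. Its size is only a floor because of the limit of > 2 h in this assay, at which 1 of the 3 values shown sits. That step points to a lower number, but carbamoyl rather than methoxy enters there, so it gives only a weak lean. No step beyond the scatter is expected in this assay.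

The estimate amounts to an expected 1.2-fold lower number from compound 2 to compound 4 (0.09 log units; within the scatter). For compound 4 the estimated half-life is 0.6 h, with an expected range of 0.3 h to 1.2 h.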

Compound 4, half-life: 0.767 h
The estimate for compound 4 lay 1.3-fold (0.11 log units) below the measured number; the measured number falls inside the stated range.
By their numbers in this assay, from the lowest: compounds 2, 4 and 3 (each within the scatter of the next). At a limit, above all of these: compound 1.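

In this assay, 5-methoxypyridin-2-yl in place of 5-(trifluoromethyl)pyridin-2-yl gives a 1.0-fold higher number from compound 2 to compound 4 (0.02 log units; within the scatter), so on this pyridine the two groups cannot be told apart by half-life. This is the only step shown that removes trifluoromethyl and has a number at both ends, and it sits on a six-membered aromatic ring with 1 nitrogen, with methoxy as the entering group. Compound 1 reports a limit, so the earlier step that removes trifluoromethyl, with carbamoyl entering, gives only a floor: the limit of > 2 h in this assay, at which 1 of the 4 values shown sits.

Two groups at one position cannot show whether half-life responds to this position at all; an amine, a carboxylic acid or a longer alkoxy chain there would test that. As far as these compounds go, whether methoxy behaves the same way in place of trifluoromethyl on the arm of compound 1 also stays open.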